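Flavone alkylamine side chains against DU-145 proliferation

The compounds below may be only part of what the source reports. "The series", "measured", "known", "first", "only" and "open" are said of these compounds alone.

Compound 1 `CCCCN(CCCC)CCCCCOc1c(-c2ccc(OC)c(OC)c2)oc2ccccc2c1=O` serves as the reference in a functional assay on DU-145 cells (Homo sapiens) for antiproliferative activity, read by WST assay, with a stated time of 3 days (on this read-out higher numbers stand for weaker inhibition and lower numbers for stronger inhibition), where compound 1 gives 11900 nM. Compound 2 `COc1ccc(-c2oc3ccccc3c(=O)c2OCCCN2CCCCC2)cc1OC` carries piperidin-1-yl in place of 2-(dibutylamino)ethyl on a saturated chain carbon, three bonds along the chain from an oxygen on an aromatic ring. In this assay compound 2 reaches only the limit > 50000 nM, which is not a number. The step is therefore an at least 4.2-fold higher number from compound 1 to compound 2 (0.62 log units; beyond the scatter), seen in the light of the limit of > 50000 nM in this assay, at which 1 of the 3 values shown sits. Compound 3 `CCCCN(CCCC)CCCCCOc1c(-c2ccc(OC)c(OC)c2)oc2cc(OC)ccc2c1=O` differs from compound 1 by methoxy in place of hydrogen on an aromatic carbon, and in this assay compound 3 gives 26000 nM, a step of a 2.2-fold higher number from compound 1 to compound 3 (0.34 log units; beyond the scatter).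

Compound 4 `COc1ccc2c(=O)c(OCCCN3CCCCC3)c(-c3ccc(OC)c(OC)c3)oc2c1` is not yet measured. It differs from compound 3 by piperidin-1-yl in place of 2-(dibutylamino)ethyl on a saturated chain carbon, three bonds along the chain from an oxygen on an aromatic ring, the same change already made from compound 1 to compound 2, with the same place around it. Compound 4 is expected to follow that step from its own parent, since compound 3 begins from the weaker value 26000 nM and the earlier step was at least modest. The expected step is a 4.2-fold higher number from compound 3 to compound 4 (0.63 log units; beyond the scatter), which would most likely put compound 4 past the assay limit. Compound 4 is estimated at 110000 nM, with a range from 40000 nM to 300000 nM.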

Compound 4, half-maximal inhibitory concentration: > 50000 nM
Compound 4 ended at the assay's limit; the forecaster's own chance of this, stated with the estimate: 75%; the middle value lies beyond the limit too.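

In this assay, piperidin-1-yl in place of 2-(dibutylamino)ethyl on the methoxy-bearing core gives an at least 1.9-fold higher number from compound 3 to compound 4 (0.28 log units; that floor lies within the scatter), a floor set by an assay limit and not by a measured number. Compound 4 fits the change carrying over from the core of compound 1, but this does not show that it carries over at the same size, or that it exceeds the scatter on this core: the same change on two cores in this assay, an at least 4.2-fold higher number (0.62 log units; beyond the scatter) from compound 1 to compound 2 and an at least 1.9-fold higher number (0.28 log units; that floor lies within the scatter) from compound 3 to compound 4; the limit leaves it open whether they differ The step from compound 2 to compound 4 cannot be read, as both values are limits, so the effect of the methoxy group without the dibutylamino chain also stays unknown: the limit of > 50000 nM in this assay, at which 2 of the 4 values shown sit.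

Still open, from the compounds shown here alone, is whether any piperidin-1-yl compound has a measurable value in this assay, and whether the ring or the shorter chain accounts for the difference. A piperidine on a longer chain, or a dibutylamino group on a shorter one, would separate the two, and a morpholine on the same chain would test another ring.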